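Notes: methyl for methoxy on compound 1

The source may report more compounds than this note shows. Statements on the series, on what has been measured and on what is new or still open speak of the compounds shown alone.

Measured in a toxicity assay on MT4 cells (Homo sapiens) for cytotoxicity, read by MTT assay; on this read-out lower numbers stand for higher toxicity in this test and higher numbers for lower toxicity in this test:
- compound 1 `COc1cc(-c2ccc(C#N)cc2)ccc1Oc1cc(N)nc(Nc2ccc(C#N)cc2)n1`: 120000 nM
- compound 2 `COc1cccc(-c2cc(C)c(Oc3cc(N)nc(Nc4ccc(C#N)cc4)n3)c(C)c2)c1`: 19300 nM
- compound 3 `Cc1cc(-c2cccc(C#N)c2)cc(C)c1Oc1cc(N)nc(Nc2ccc(C#N)cc2)n1`: 20200 nM

Compound 1 stands highest of the three numbers, beyond the scatter from both others. The change to compound 4 `Cc1cc(-c2ccc(C#N)cc2)ccc1Oc1cc(N)nc(Nc2ccc(C#N)cc2)n1` is methyl in place of methoxy on an aromatic carbon. Among the compounds with values here, the only measured step, a 1.0-fold higher number from compound 2 to compound 3 (0.02 log units; within the scatter), is a different exchange, lies within the scatter and does not test this change. Compound 2 at 19300 nM and compound 3 at 20200 nM carry methyl groups, but they differ from compound 4 in more than one place, so they are only a loose guide. A moderate fall in this assay is therefore expected. The estimated step is a 2.7-fold lower number from compound 1 to compound 4 (0.43 log units; beyond the scatter). Compound 4 is estimated at 45000 nM, with a range of 15000 nM to 120000 nM.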

Compound 4, half-maximal cytotoxic concentration: 10400 nM
The estimate for compound 4 lay 4.3-fold (0.64 log units) above the measured number; the measured number lies below the stated range.
By their numbers in this assay, from the lowest: compounds 4, 2 and 3 (each within the scatter of the next); then compound 1.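

In this assay, methyl in place of methoxy on an aromatic carbon, ortho to a large group, gives a large step (a 12-fold lower number from compound 1 to compound 4 (1.06 log units; beyond the scatter)). Compound 1 and compound 4 are the only pair shown that isolates this position, and the single exchange is enough to carry the number well beyond the scatter. Nothing available accounts for the size of this step.

On these data alone, whether an amine, a chlorine atom or an ethyl group at this position would follow methyl or methoxy remains open. Also open, as far as these compounds go, is whether the same exchange gives a similar step with a group other than the 4-cyanophenyl group on this ring.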